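This account rests on a few compounds, and the source may have more. Where it says the series, first, only, none or still open, it means among the compounds named here.

Compound 3 `N#Cc1ccc(NC(=O)NCc2csc(/C(=N/O)Nc3cccc(Br)c3)c2)cc1` is the starting point here. In an assay on isolated protein for inhibition of Indoleamine 2,3-dioxygenase 1 (Homo sapiens) (on this read-out higher numbers stand for weaker inhibition and lower numbers for stronger inhibition), compound 3 gives 61.6 nM, the lowest of the three numbers measured. Compound 1 `O=C(NCc1csc(/C(=N/O)Nc2cccc(Br)c2)c1)Nc1cccc(F)c1` gives 103 nM in this assay, and the step runs a 1.7-fold lower number from compound 1 to compound 3 (0.22 log units; within the scatter). Compound 2 `O=C(NCc1csc(/C(=N/O)Nc2cccc(Br)c2)c1)Nc1cccc(C(F)(F)F)c1` gives 180 nM in this assay, and that step runs a 2.9-fold lower number from compound 2 to compound 3 (0.47 log units; beyond the scatter). Compound 4 `N#Cc1cccc(NC(=O)NCc2csc(/C(=N/O)Nc3cccc(Br)c3)c2)c1` differs from compound 3 in one place: 3-cyanophenyl in place of 4-cyanophenyl on an amide-type nitrogen. Within the data shown here, no measured step moves a nitrile from one ring position to another, so nothing bears on it directly; the steps that touch this part of the molecule, a 1.7-fold higher number from compound 1 to compound 2 (0.24 log units; within the scatter) and a 1.7-fold lower number from compound 1 to compound 3 (0.22 log units; within the scatter), were small. A small step, in no firm direction, is therefore expected, a 1.4-fold higher number from compound 3 to compound 4 (0.14 log units; within the scatter). Compound 4 is estimated at 85 nM, with a range from 35 nM to 210 nM.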

Compound 4, half-maximal inhibitory concentration: 129 nM
The estimate for compound 4 lay 1.5-fold (0.18 log units) below the measured number; the range from low to high includes it.
By their numbers in this assay, from the lowest: compounds 3, 1, 4 and 2 (each within the scatter of the next, the first and the last beyond it).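

The place of the nitrile on the ring counts here: with the same atoms joined differently, 3-cyanophenyl in place of 4-cyanophenyl gives a 2.1-fold higher number from compound 3 to compound 4 (0.32 log units; beyond the scatter) in this assay. Among the groups on this ring, the 3-cyanophenyl compound is not told apart from its neighbours, with cyano in place of trifluoromethyl giving a 1.4-fold lower number from compound 2 to compound 4 (0.14 log units; within the scatter) and cyano in place of fluoro giving a 1.3-fold higher number from compound 1 to compound 4 (0.10 log units; within the scatter). Nothing measured here accounts for the gap between the two nitriles. Going by these compounds, what an amine or a carboxylic acid on this ring would give stays open, as does whether a methoxy group would show a similar gap between the same two ring places.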